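Removing an Amide Side Chain from a Kinase Inhibitor

The compounds below may be only part of what the source reports. "The series", "measured", "known", "first", "only" and "open" are said of these compounds alone.

Of the compounds shown here, two have so far been measured in an assay for inhibition of serine/threonine-protein kinase PLK2 (Homo sapiens), read by FRET and Z'-LYTE, with a stated time of 1 h; on this read-out higher numbers stand for weaker inhibition and lower numbers for stronger inhibition. Compound 1 `CCCNS(=O)(=O)c1ccc(Nc2ncc3c(n2)N(c2ccn(C)n2)C(CC)C(=O)N3C)cc1` gives 190 nM in this assay. Compound 2 `CC[C@@H]1C(=O)N(C)c2cnc(-n3ccc4cc(C(=O)NCC(C)C)ccc43)nc2N1C1CCCC1` gives 18.6 nM, the lowest of the two numbers; compound 1 stands a full step away from it, beyond the usual scatter, so compound 2 is the stronger inhibitor of the pair. Compound 3 `CC[C@@H]1C(=O)N(C)c2cnc(-n3ccc4ccccc43)nc2N1C1CCCC1` has not yet been measured. It differs from compound 2 in a single place: hydrogen in place of isobutylcarbamoyl on an aromatic carbon. Among the measured compounds shown here, no pair of measured compounds shows a change of this kind, so its effect on the read-out is not known from what has been measured. A modest weakening is expected, a step of a 2.7-fold higher number from compound 2 to compound 3 (0.43 log units; beyond the scatter), and this lies beyond the scatter only at its upper end. Compound 3 is estimated at 50 nM, with a likely range from 15 nM to 180 nM.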

Compound 3, half-maximal inhibitory concentration: 355 nM
For compound 3 the middle estimate is 7.1-fold (0.85 log units) below the measured one; the whole stated range lies below it.
By their numbers in this assay, from the lowest: compound 2; then compounds 1 and 3 (each within the scatter of the next).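

In this assay, replacing the isobutylcarbamoyl group on this aromatic carbon with hydrogen gives a 19-fold higher number from compound 2 to compound 3 (1.28 log units; beyond the scatter), a large step and the first direct view of what this position contributes. Much of the inhibition seen with compound 2 therefore depends on this side chain, yet compound 3 still gives a measurable value of 355 nM without it, so the rest of the molecule retains some inhibition on its own. Nothing available explains why the loss is so large.

The two compounds cannot separate the roles of the amide carbonyl, the amide hydrogen and the isobutyl chain, since all of them leave together. From the compounds shown here alone, it also remains open how a carboxylic acid, an amine or a longer chain on the amide would fare at this same position.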